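The source may hold more compounds than are shown below. What is called first, only, known or untested is meant among the compounds shown, and "the series" means these compounds.

Working notes on the series.

Of the compounds shown here, three of this set have been measured in a functional assay on CCRF-CEM cells (Homo sapiens) for antiproliferative activity, with a stated time of 72 h; on this read-out lower numbers stand for stronger inhibition and higher numbers for weaker inhibition. Compound 1, `CSc1cnc2ccccc2c1[Se]CC#CCOC(=O)c1ccc(C(=O)O)cc1`, gives 4 ug/mL in this assay. Compound 2, `CSc1cnc2ccccc2c1[Se]CC#CCOC(=O)c1ccccc1`, gives 1.9 ug/mL in this assay. Compound 3, `CSc1cnc2ccccc2c1SCC#CCOC(=O)c1ccc(C(=O)O)cc1`, gives 14.5 ug/mL in this assay, the highest of the three numbers.

Compound 1 and compound 2 differ in one place, (hydrogen in place of carboxy on an aromatic carbon), and the step is a 2.1-fold lower number from compound 1 to compound 2 (0.32 log units; beyond the scatter).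

Compound 1 and compound 3 share the same side chain and differ in their cores; the difference between the two cores is not broken down here. The values show compound 3 well above compound 1 in this assay.

Compound 4, `CSc1cnc2ccccc2c1SCC#CCOC(=O)c1ccccc1`, is not yet measured. It stands to compound 3 as compound 2 stands to compound 1: the change is hydrogen in place of carboxy on an aromatic carbon, and the place is the same in both pairs, so this is the same change, made on the core of compound 3 rather than on the core of compound 1.

Going by the values given here, for the step from compound 3 to compound 4 in this assay a step of a 2.1-fold lower number from compound 3 to compound 4 (0.32 log units; beyond the scatter) is expected, resting on the single earlier instance of this change, a 2.1-fold lower number from compound 1 to compound 2 (0.32 log units; beyond the scatter), with the caution that one prior step on a different core is a thin base. Compound 4 is therefore estimated at 7 ug/mL in this assay, with the expected range running from 3.5 ug/mL to 14 ug/mL.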

Compound 4, concentration for 50% inhibition: 22.2 ug/mL
Estimate against measurement, compound 4: 3.2-fold (0.50 log units) below; measured number above the stated range.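

In this assay replacing carboxy with hydrogen on the core of compound 3 gives a 1.5-fold higher number from compound 3 to compound 4 (0.18 log units; within the scatter), so on this core the change has no readable effect, and compound 3 and compound 4 cannot be told apart. The same change therefore does not carry over unchanged from one core to the other, and the two steps differ by more than repeated measurements would explain: the same change on two cores in this assay, a 2.1-fold lower number (0.32 log units; beyond the scatter) from compound 1 to compound 2 and a 1.5-fold higher number (0.18 log units; within the scatter) from compound 3 to compound 4, 3.2-fold (0.51 log units) apart, beyond the scatter of two such steps. This rests on a single pair on each core, so it shows that a step seen on one core cannot be assumed on the other in this series, but it does not give the reason for the difference or a rule for any further core.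

From the compounds shown here alone, with only hydrogen and carboxy at this place on the aromatic ring, it remains open whether a methyl ester, an amide or an amine there would also behave differently on the two cores. Going by these compounds, it also remains open whether the difference between the two steps would persist with a longer chain in place of the one shared by all four compounds.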